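Swapping a Carbon Ring Group for 2-Methoxyphenyl

The compounds below may be only part of what the source reports. "The series", "measured", "known", "first", "only" and "open" are said of these compounds alone.

Measured in an ADME assay on MDBK cells (Bos taurus) for cytotoxicity, read by MTT assay; a higher number here means that more compound is tolerated, a lower number that less compound is tolerated:
- Compound 1 `CCCC1CCCCC1OCCCCCCN1C[C@H](O)[C@@H](O)[C@H](O)[C@H]1CO`: 150000 nM
- Compound 2 `CC1CCCC(OCCCCCCN2C[C@H](O)[C@@H](O)[C@H](O)[C@H]2CO)C1C`: > 500000 nM

For compound 2 the assay gives no number, only a limit: > 500000 nM. It stands at the limit of > 500000 nM in this assay, at which 1 of the 2 values shown sits.

Compound 3 `COc1ccccc1OCCCCCCN1C[C@H](O)[C@@H](O)[C@H](O)[C@H]1CO` differs from compound 2 in one place: a group of 8 heavy atoms (7 carbon, 1 oxygen; one six-membered aromatic ring of carbon only) in place of a group of 8 heavy atoms (8 carbon; one six-membered non-aromatic ring of carbon only), on an oxygen on a saturated carbon. The 2-methoxyphenyl group sits on an oxygen on a saturated carbon. One measured step changes the group at that same place: an at least 3.3-fold higher number from compound 1 to compound 2 (0.52 log units; beyond the scatter). Within the data shown here, that step exchanged one non-aromatic carbon ring group for another, and no measured compound carries an aromatic ring there. Among the measured compounds shown here, its size, which is beyond the scatter, is the only guide. A modest fall in this assay is therefore expected, or no change that can be read, since another limit is possible. The expected change is an at least 1.2-fold lower number from compound 2 to compound 3 (0.09 log units; that floor lies within the scatter). For compound 3 the estimated value is 400000 nM, with an expected range of 150000 nM to 500000 nM.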

Compound 3, half-maximal cytotoxic concentration: > 500000 nM
Compound 3 ended at the assay's limit; the forecaster's own chance of this, stated with the estimate: 55%; middle value at least 1.2-fold (0.09 log units) from the limit.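

In this assay compound 3 gives > 500000 nM, which is a limit and not a number, and it is the first compound shown with an aromatic ring group at this place. The change that can be read is an at least 3.3-fold higher number from compound 1 to compound 3 (0.52 log units; beyond the scatter), which shows that a non-aromatic carbon ring is not needed on this oxygen for the higher number. The step from compound 2 to compound 3 cannot be read, and neither compound can be ranked against the other: the limit of > 500000 nM in this assay, at which 2 of the 3 values shown sit.

On these data alone, whether an aromatic ring group differs at all from the non-aromatic one in this assay therefore stays open. Also open, as far as these compounds go, is what an unsubstituted phenyl group, a pyridine ring or a 2-hydroxyphenyl group would give on the same oxygen.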